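This account rests on a few compounds, and the source may have more. Where it says the series, first, only, none or still open, it means among the compounds named here.

- Compound 1 `Cc1ccc(S(=O)(=O)N2CCN(c3noc4cccc(Cl)c34)CC2)cc1`: 116 ug/mL
- Compound 2 `O=S(=O)(c1ccc(OC(F)(F)F)cc1)N1CCN(c2noc3cccc(Cl)c23)CC1`: 59.3 ug/mL

In an ADME assay on RAW264.7 cells (Mus musculus) for inhibition, read by MTT assay, with a stated time of 72 h (on this read-out higher numbers stand for weaker inhibition and lower numbers for stronger inhibition), compound 2 gives 59.3 ug/mL, which lies within the scatter of compound 1 at 116 ug/mL. Compound 3 `O=S(=O)(c1ccc(OC(F)(F)F)cc1)N1CCN(c2noc3cc(Cl)ccc23)CC1` has the same atoms as compound 2, joined differently: a group of 10 heavy atoms (7 carbon, 1 nitrogen, 1 oxygen, 1 chlorine; one five-membered aromatic ring with 2 hetero atoms, one six-membered aromatic ring of carbon only) in place of a group of 10 heavy atoms (7 carbon, 1 nitrogen, 1 oxygen, 1 chlorine; one five-membered aromatic ring with 2 hetero atoms, one six-membered aromatic ring of carbon only), on an amine nitrogen in a ring. Among the compounds with values here, the only measured step, a 2.0-fold lower number from compound 1 to compound 2 (0.29 log units; within the scatter), comes from trifluoromethoxy in place of methyl on an aromatic carbon, so it does not test this change. No step beyond the scatter is therefore expected in this assay. The expected step is a 1.0-fold higher number from compound 2 to compound 3 (0.01 log units; within the scatter). For compound 3 the estimated value is 60 ug/mL, with an expected range of 25 ug/mL to 140 ug/mL.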

Compound 3, half-maximal inhibitory concentration: 138 ug/mL
Beside the measured number, compound 3's estimate is 2.3-fold (0.36 log units) below it, within the range that was stated.
By their numbers in this assay, from the lowest: compounds 2, 1 and 3 (each within the scatter of the next, the first and the last beyond it).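

In this assay joining the same atoms differently within the group on the amine nitrogen in a ring gives a 2.3-fold higher number from compound 2 to compound 3 (0.37 log units; beyond the scatter) and thus a modest change. This position therefore responds to how that group is joined, even with its heavy atoms, ring types and hydrogen-bond counts unchanged. Unlike the trifluoromethoxy for methyl change, this step lies beyond the scatter. No available evidence accounts for it. On these data alone, whether fluorine or a methoxy group in place of the chlorine would shift the number remains open, as does whether this step would recur with the methyl group of compound 1 in place of trifluoromethoxy.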